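The source may report more compounds than this note shows. Statements on the series, on what has been measured and on what is new or still open speak of the compounds shown alone.

Measured so far:
- compound 1 `COc1ccc(C2=C(c3ccc(SC)cc3)CC3CCCN3C2=O)cc1C`: 900 nM
- compound 2 `CSc1ccc(C2=C(c3ccc(O)c(O)c3)C(=O)N3CCCC3C2)cc1`: 60000 nM
- compound 3 `CSc1ccc(C2=C(c3ccc(Br)cc3)C(=O)N3CCCC3C2)cc1`: 9000 nM

In a functional assay on DU-145 cells (Homo sapiens) for cytotoxicity (a lower number here means a stronger inhibitor of growth, a higher number a weaker inhibitor of growth), compound 3 gives 9000 nM, the middle of the three numbers: a weaker growth inhibitor than compound 1, a stronger one than compound 2. Compound 4 `CSc1ccc(C2=C(c3ccc(C)cc3)C(=O)N3CCCC3C2)cc1` differs from it in one place: methyl in place of bromo on an aromatic carbon. Within the data shown here, no measured pair makes this exact swap. The nearest evidence is a 10-fold higher number from compound 1 to compound 3 (1.00 log units; beyond the scatter) and a 6.7-fold lower number from compound 2 to compound 3 (0.82 log units; beyond the scatter), both modest, and each exchanges a differently substituted phenyl group rather than a single group on it. A much smaller step is therefore expected here, with no firm direction. The expected change is a 1.5-fold lower number from compound 3 to compound 4 (0.18 log units; within the scatter), within the scatter. Compound 4 is estimated at 6000 nM, with an expected range of 2000 nM to 20000 nM.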

Compound 4, concentration for 50% growth inhibition: 600 nM
Estimate against measurement, compound 4: 10-fold (1.00 log units) above; the measured number lies below the stated range.
By their numbers in this assay, from the lowest: compounds 4 and 1 (each within the scatter of the next); then compound 3; then compound 2.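

In this assay, this position on the ring responds strongly to a change of one heavy atom: methyl in place of bromo gives a 15-fold lower number from compound 3 to compound 4 (1.18 log units; beyond the scatter). The 4-methylphenyl group also gives a 100-fold lower number from compound 2 to compound 4 (2.00 log units; beyond the scatter) and a 1.5-fold lower number from compound 1 to compound 4 (0.18 log units; within the scatter), so the 4-methylphenyl and 4-methoxy-3-methylphenyl groups cannot be told apart here. No evidence shown accounts for the size of the methyl-for-bromo step. Still open, as far as these compounds go, is whether an ethyl chain, an amine or a carboxylic acid at this position would keep the number close to that of compound 4.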